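From Methoxy to Nitro on an Unanchored Scale

The source may hold more compounds than are shown below. What is called first, only, known or untested is meant among the compounds shown, and "the series" means these compounds.

Compounds measured in an ADME assay on HUVEC cells (Homo sapiens) for cytotoxicity, read by MTT assay, with a stated time of 72 h; on this read-out higher numbers stand for weaker inhibition and lower numbers for stronger inhibition:
- Compound 1 `COc1cc(-c2nccn2-c2cccc(C)c2)cc(OC)c1OC`: > 100000 nM
- Compound 2 `COc1cccc(-n2ccnc2-c2cc(OC)c(OC)c(OC)c2)c1`: "not determined" (no result reported)

Compound 2 has no place on the numbers, since its entry reads "not determined" (no result reported). Among the compounds with values here, the only other reading is that of compound 1, and its > 100000 nM is a limit of the assay and not a number.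

Compound 3 `COc1cc(-c2nccn2-c2cccc([N+](=O)[O-])c2)cc(OC)c1OC` is still unmeasured. The structural change is nitro in place of methoxy on an aromatic carbon, which puts nitro in place of methoxy on an aromatic carbon, meta to a large group. Within the data shown here, with no measured step to size this change, no step beyond the usual scatter is expected in this assay. That expectation rests only on compound 1, which reads > 100000 nM, so it is a weak guide. Compound 3 is estimated at 80000 nM, with an expected range of 25000 nM to 100000 nM.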

Compound 3, half-maximal inhibitory concentration: > 100000 nM
Compound 3: no number, only a limit; the forecaster's own chance of this, stated with the estimate: 60%; at least 1.2-fold (0.09 log units) between middle value and limit.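

Within the data shown here, compound 1 and compound 3 both end at a limit and not at a number, so no step between them can be read, because the two readings stop at the same point: the limit of > 100000 nM in this assay, at which 2 of the 3 values shown sit. Going by these compounds, how far either compound lies past that limit in this assay stays open, as does where compound 2 stands.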